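The source may report more compounds than this note shows. Statements on the series, on what has been measured and on what is new or still open speak of the compounds shown alone.

Compound 1 `Cc1cccc(OC[C@@H]2[C@H]3CC[C@H](c4nc(C(=O)O)cs4)O[C@H]3C[C@H]2O)c1` gives 3.6 nM in a functional assay on CHO cells for agonist activity at prostaglandin E2 receptor EP2 subtype (Homo sapiens), read by HTRF and cAMP accumulation, with a stated time of 30 min (a lower number here means that less compound is needed, a higher number that more compound is needed for the effect), the lowest of the three numbers at hand; compound 3 `O=C(O)c1csc([C@H]2CC[C@@H]3[C@@H](/C=C/COc4ccccc4)[C@H](O)C[C@@H]3O2)n1` at 3.8 nM and compound 2 `O=C(O)c1csc([C@H]2CC[C@@H]3[C@@H](COc4ccc(F)cc4)[C@H](O)C[C@@H]3O2)n1` at 7 nM both fall within the scatter of it. Within the data shown here, the single measured step, a 1.9-fold higher number from compound 1 to compound 2 (0.29 log units; within the scatter), shows nothing beyond the scatter. Compound 4 `O=C(O)c1csc([C@H]2CC[C@@H]3[C@@H](CCCOc4ccccc4)[C@H](O)C[C@@H]3O2)n1` differs from compound 1 by 2-phenoxyethyl in place of 3-methylphenoxy on a saturated chain carbon bound to a saturated ring carbon. Among the measured compounds shown here, no measured step bears directly on this exchange; the nearest comparison is compound 3, which also bears a chain ending in phenoxy on the shared core and sits within the scatter of compound 1, so a step in this assay beyond the scatter is not expected. For compound 4 the expected number is 5 nM, with a range of 2 nM to 12 nM, meaning an estimated step of a 1.4-fold higher number from compound 1 to compound 4 (0.14 log units; within the scatter).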

Compound 4, half-maximal effective concentration: 10 nM
Compound 4: the middle estimate sits 2.0-fold (0.30 log units) below what was measured, and the stated range covers the measured number.
By their numbers in this assay, from the lowest: compounds 1, 3, 2 and 4 (each within the scatter of the next, the first and the last beyond it).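

On a saturated chain carbon bound to a saturated ring carbon, 2-phenoxyethyl in place of 3-methylphenoxy gives the first listed step beyond the scatter in this assay: a 2.8-fold higher number from compound 1 to compound 4 (0.44 log units; beyond the scatter). The same group in place of 4-fluorophenoxy gives a 1.4-fold higher number from compound 2 to compound 4 (0.15 log units; within the scatter), so the exchange leaves the scatter against only one of the two aryloxy groups, and only modestly. Nothing at hand accounts for this difference.

Still open, on these data alone, is how a longer chain, or an amine in place of the chain's ether oxygen, would read in this assay. Also open, as far as these compounds go, is whether a methyl or fluorine on the ring of 2-phenoxyethyl would shift the number.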